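A few compounds are considered here, and "the series" means these few. Any claim that something is new, unique, unknown or untested is made for them only; others in the source may bear on it.

Going by the values given here, compound 1, with structure `COc1ccc(/C=C/C(=O)c2ccc(OC)c3c2OC(C)(C)C=C3)c(F)c1`, is the only compound here that returns a number: in a functional assay on SW-620 cells (Homo sapiens) for antiproliferative activity, read by MTT assay, with a stated time of 24 h (on this read-out lower numbers stand for stronger inhibition and higher numbers for weaker inhibition), compound 1 gives 6570 nM. Compound 2, with structure `COc1ccc(C(=O)/C=C/c2ccc(OC)c(OC)c2OC)c2c1C=CC(C)(C)O2`, does not; in this assay compound 2 stops at a limit of the assay, reported as > 10000 nM. This is the limit of > 10000 nM in this assay, at which 1 of the 2 values shown sits, and it says nothing about how far beyond the limit compound 2 lies. Compound 3, with structure `COc1ccc(C(=O)/C=C/c2ccsc2)c2c1C=CC(C)(C)O2`, has not yet been measured. It differs from compound 1 in one place: thiophen-3-yl in place of 2-fluoro-4-methoxyphenyl on a double-bonded chain carbon bound to a double-bonded chain carbon. Among the compounds with values here, no measured pair here carries such a change, so the expectation rests on compound 1 alone. The expected step, a 1.3-fold higher number from compound 1 to compound 3 (0.11 log units; within the scatter), is small and leans toward weaker inhibition, quite possibly within the usual scatter. Compound 3 is therefore estimated at 8500 nM in this assay, with a range from 2500 nM to 25000 nM.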

Compound 3, half-maximal inhibitory concentration: > 10000 nM
Compound 3: no number, only a limit; the forecaster's own chance of this, stated with the estimate: 35%; at least 1.1-fold (0.07 log units) between middle value and limit.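

Going by these compounds alone, compound 3 is the first compound here with a change at this place on the chain, and an at least 1.5-fold higher number from compound 1 to compound 3 (0.18 log units; that floor lies within the scatter) is what thiophen-3-yl in place of 2-fluoro-4-methoxyphenyl gives in this assay, with no sign of stronger inhibition. The value of compound 3 is a limit and not a number, so this step is only a floor, and that floor does not clear the usual scatter. Compound 3 thus joins compound 2 at the same limit, which now holds most of the values shown: the limit of > 10000 nM in this assay, at which 2 of the 3 values shown sit.

On these data alone, how far compound 3 lies beyond the limit stays open, so the true size of this step could be small or large. Also open, as far as these compounds go, is how this assay would respond to an unsubstituted phenyl ring or an amine at this place.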